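Chloro for hydroxy on compound 1: working notes

This account rests on a few compounds, and the source may have more. Where it says the series, first, only, none or still open, it means among the compounds named here.

Measured so far:
compound 1 `COc1cc2c(/C=C3/C(=O)Nc4ccc(O)cc43)c(Cl)n(Cc3cc(OC)c(OC)c(OC)c3)c2cc1C` — 2290 nM
compound 2 `O=C1Nc2ccccc2/C1=C\c1c(Cl)n(Cc2ccccc2)c2ccccc12` — 20000 nM

In a functional assay on cells (Cancer cell lines, Homo sapiens) for cytotoxicity, with a stated time of 48 h (a lower number here means a stronger inhibitor of growth, a higher number a weaker inhibitor of growth), compound 1 gives 2290 nM and compound 2 gives 20000 nM. Compound 1 carries the lower of the two numbers, and the gap between them lies beyond the scatter. The two compounds differ in several places at once, so no single structural step can be read from them.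

Compound 3 `COc1cc2c(/C=C3/C(=O)Nc4ccc(Cl)cc43)c(Cl)n(Cc3cc(OC)c(OC)c(OC)c3)c2cc1C` is compound 1 with chloro in place of hydroxy on an aromatic carbon. Going by the values given here, no measured pair isolates this change, so its direction rests on no data. A modest step in this assay, more likely toward a weaker inhibitor than a stronger one, is expected. Compound 3 is expected to give 3500 nM with a range from 1200 nM to 11000 nM. The estimated step is a 1.5-fold higher number from compound 1 to compound 3 (0.18 log units; within the scatter).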

Compound 3, concentration for 50% growth inhibition: 2190 nM
Compound 3: middle estimate off by 1.6-fold (0.20 log units), on the high side; low and high end bracket the measured number.
By their numbers in this assay, from the lowest: compounds 3 and 1 (each within the scatter of the next); then compound 2.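

In this assay, chloro in place of hydroxy on this aromatic carbon of the shared core leaves compounds 1 and 3 level (a 1.0-fold lower number from compound 1 to compound 3 (0.02 log units; within the scatter)). Going by these compounds alone, this is the first single-place step, and at this position the hydrogen-bond donor and acceptor counted for hydroxy can go with no change beyond the scatter. No supporting evidence bears on why the two groups read alike.

Still open, on these data alone, is whether an amine or a carboxylic acid on this carbon would also read level. Whether the same swap holds on a core with other substituents is also unresolved.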